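The source may hold more compounds than are shown below. What is called first, only, known or untested is meant among the compounds shown, and "the series" means these compounds.

Of the compounds shown here, two have so far been measured in an assay on nucleic acid for inhibition of Nucleic Acid, read by fluorescence, tested at 100 uM; on this read-out higher numbers stand for more inhibition at the one concentration tested (going by the name of the read-out) and lower numbers for less inhibition. Compound 1 `CC(C)CCN(C)Cc1cn(C2CCCCC2OC(=O)c2ccccc2)nn1` gives 26% in this assay, and compound 2 `CCCCN(CCCC)Cc1cn(CC(O)COC(=O)NCc2ccccc2)nn1` gives 42%. Of these two numbers, compound 1 stands lowest; the value of compound 2 lies higher by a gap beyond the usual scatter. The two compounds differ in several places at once, however, so no more is read from the pair than what their two values show.

Compound 3 `CC(C)CCN(C)Cc1cn(C2CCCCC2O)nn1` has not yet been measured in this assay. It differs from compound 1 in one place: hydrogen in place of benzoyl on an oxygen on a saturated carbon. Within the data shown here, no single-change step between measured compounds is available, so the size of this step cannot be read off and can only be expected. The step expected here is a number 6 percentage points lower from compound 1 to compound 3 (within the scatter), a change that is thought to stay within the usual scatter, if anything pointing downward. On that basis compound 3 is estimated to give 20% in this assay, with an expected range from 5% to 40%.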

Compound 3, a percentage reported as inhibition, at one concentration (the size of the read-out at that concentration, not a potency): 42%
Compound 3: the middle estimate sits 22 percentage points below what was measured, and the stated range ends below it.
By their numbers in this assay, from the lowest: compound 1; then compounds 2 and 3 (each within the scatter of the next).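

At the oxygen on a saturated carbon of the core of compound 1, replacing the benzoyl with hydrogen, which reads as benzoyloxy to hydroxy, gives a number 16 percentage points higher from compound 1 to compound 3 (beyond the scatter) in this assay. Among these compounds, this is the first single-change step, and it shows that the benzoyl, with its aromatic ring and carbonyl, is not required for the inhibition seen at this position, since the read-out goes up rather than down once the whole group has left. Nothing measured here accounts for the direction or size of this step, so it stands as an observation from one pair of compounds.

A single pair cannot show which part of the benzoyl goes with the lower number, and an acetyl group on the same oxygen, which keeps the carbonyl without the aromatic ring, or a methyl group, which leaves a simple ether, would separate those parts. Also open, going by these compounds, is whether the same change gives a step of similar size when the amine side chain of compound 1 is replaced, for example by a dibutylamine.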